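Working notes: a new group on the amide chain

A few compounds are considered here, and "the series" means these few. Any claim that something is new, unique, unknown or untested is made for them only; others in the source may bear on it.

Values in a functional assay on Fem-X cells (Homo sapiens) for cytotoxicity; a lower number here means a stronger inhibitor, a higher number a weaker inhibitor:
compound 1 `O=C(O)C1CCC2(CC1)OOC1(CCCCC1)OO2`: 155000 nM
compound 2 `CCCNC(=O)C1CCC2(CC1)OOC1(CCCCC1)OO2`: 102000 nM

For the measured compounds named here, compound 2 stands level, within the scatter, with compound 1, the only other measured compound in this assay. Going by the values given here, the one measured step, a 1.5-fold lower number from compound 1 to compound 2 (0.18 log units; within the scatter), puts propylamino in place of hydroxy on a carbonyl carbon.

The next compound is compound 3 `CN(C)CCNC(=O)C1CCC2(CC1)OOC1(CCCCC1)OO2`, with this difference: dimethylamino in place of methyl on a saturated chain carbon, two bonds along the chain from an amide-type nitrogen. In words, this is dimethylamino in place of methyl on a saturated chain carbon, two bonds along the chain from an amide-type nitrogen.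

Among the compounds with values here, the measured step touches a different change, and no measured compound carries dimethylamino, so the data offer only weak guidance. No step beyond the scatter is expected, and the expected step is a 1.7-fold lower number from compound 2 to compound 3 (0.23 log units; within the scatter). For compound 3 the estimated value is 60000 nM, with an expected range of 15000 nM to 160000 nM.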

Compound 3, half-maximal inhibitory concentration: 120000 nM
Compound 3: the middle estimate sits 2.0-fold (0.30 log units) below what was measured; the range from low to high includes it.
By their numbers in this assay, from the lowest: compounds 2, 3 and 1 (each within the scatter of the next).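

In this assay, dimethylamino in place of methyl on a saturated chain carbon, two bonds along the chain from an amide-type nitrogen, gives a 1.2-fold higher number from compound 2 to compound 3 (0.07 log units; within the scatter), so this position takes the change without a step beyond the scatter. Taken from the carboxylic acid, the step reads a 1.3-fold lower number from compound 1 to compound 3 (0.11 log units; within the scatter), which leaves all three compounds level within the scatter in this assay. No measurement at hand bears on the reason for this result.

Going by these compounds, whether a primary amine or a longer chain ending in dimethylamino would move the number beyond the scatter remains open. With no step beyond the scatter so far, the compounds shown do not yet identify any change on the amide chain that matters in this assay.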